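From Hydroxy to Chloro: An Estimate for Compound 3

The source may report more compounds than this note shows. Statements on the series, on what has been measured and on what is new or still open speak of the compounds shown alone.

Compound 1 `COc1ccc(C(=O)/C=C/c2cc3ccccc3[nH]c2=O)cc1` gives 26900 nM in an ADME assay on KM12 cells (Homo sapiens) for cytotoxicity, read by sulforhodamine B assay, with a stated time of 24 h; on this read-out lower numbers stand for higher toxicity in this test and higher numbers for lower toxicity in this test.
Compound 2 `O=C(/C=C/c1cc2ccccc2[nH]c1=O)c1ccc(O)cc1` gives 15400 nM in this assay.

Within the data shown here, compound 2 has the lower of these two numbers, but its only neighbour, compound 1, lies within the scatter, so no order between them can be claimed. Among the measured compounds shown here, the single measured step, a 1.7-fold lower number from compound 1 to compound 2 (0.24 log units; within the scatter), is a change on the oxygen of the same ring position and stays within the scatter.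

Compound 3 `O=C(/C=C/c1cc2ccccc2[nH]c1=O)c1ccc(Cl)cc1` differs from compound 2 by chloro in place of hydroxy on an aromatic carbon, on an aromatic carbon of a six-membered aromatic ring of carbon only, para to a large group. For the measured compounds named here, no measured step covers a hydroxy to chloro exchange, and the one step at this position was within the scatter, so compound 3 is expected to show a 1.2-fold higher number from compound 2 to compound 3 (0.07 log units; within the scatter), nothing beyond the scatter. Compound 3 is therefore estimated at 18000 nM, in the range 7000 nM to 45000 nM.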

Compound 3, concentration lethal to 50% of the cells: 98900 nM
Compound 3: the middle estimate sits 5.5-fold (0.74 log units) below what was measured, and the stated range ends below it.
By their numbers in this assay, from the lowest: compounds 2 and 1 (each within the scatter of the next); then compound 3.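

With chloro on this six-membered aromatic ring of carbon only, para to a large group, this assay shows a 6.4-fold higher number from compound 2 to compound 3 (0.81 log units; beyond the scatter) and a 3.7-fold higher number from compound 1 to compound 3 (0.57 log units; beyond the scatter). Both steps lie beyond the scatter, so a single exchange at this place can shift the read-out towards lower toxicity in this test, something the hydroxy and methoxy pair, within the scatter of each other, could not show. No available evidence bears on what lies behind this difference.

As far as these compounds go, whether the shift belongs to chloro in particular stays open, as does what fluoro, bromo, methyl or an amine would give at this same place. The compounds shown also leave open whether the same exchange would give a similar step on a changed core.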